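The source may hold more compounds than are shown below. What is called first, only, known or untested is meant among the compounds shown, and "the series" means these compounds.

Measured so far:
compound 1, `C(=N/Nc1nc(-c2ccccc2)cs1)\c1ccccc1`: 1200 nM
compound 2, `Cc1csc(N/N=C/c2ccc(Cl)cc2)n1`: 38 nM

In an assay on mitochondria for inhibition of Amine oxidase [flavin-containing] A (Bos taurus) (a lower number here means a stronger inhibitor, a higher number a weaker inhibitor), compound 2 gives the lowest of the two numbers; compound 1 sits far above it, beyond the scatter, but the two differ in more than one place. Compound 3, `Clc1ccc(/C=N/Nc2nc(-c3ccccc3)cs2)cc1`, is unmeasured. It keeps the chlorinated ring of compound 2 and changes only one site: phenyl in place of methyl on an aromatic carbon. Compound 1, which also carries the phenyl on the core, gives 1200 nM, so a weakening is expected. Compound 3 is estimated at 200 nM, range 40 nM to 1200 nM, an expected step of a 5.3-fold higher number from compound 2 to compound 3 (0.72 log units; beyond the scatter).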

Compound 3, inhibition constant: 100 nM
The estimate for compound 3 lay 2.0-fold (0.30 log units) above the measured number; measured number inside the range.
By their numbers in this assay, from the lowest: compound 2; then compound 3; then compound 1.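

In this assay the aromatic carbon next to the ring nitrogen accepts phenyl in place of methyl at a modest cost, with a 2.6-fold higher number from compound 2 to compound 3 (0.42 log units; beyond the scatter) as the step. With phenyl held in place, chloro in place of hydrogen on an aromatic carbon gives a 12-fold lower number from compound 1 to compound 3 (1.08 log units; beyond the scatter) as a large step, so the phenyl-bearing core does not rule out strong inhibition. Nothing available accounts for either step.

Going by these compounds, whether chloro gives a similar step with methyl on the core remains open. So does how an ethyl group, an amine or a carboxylic acid would read at the position that carries methyl or phenyl.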